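From compound 2 to its 4-ethylphenyl relative

The source may report more compounds than this note shows. Statements on the series, on what has been measured and on what is new or still open speak of the compounds shown alone.

In a functional assay on UO-31 cells (Homo sapiens) for inhibition, read by sulforhodamine B assay, with a stated time of 48 h (a lower number here means a stronger inhibitor of growth, a higher number a weaker inhibitor of growth), compound 1 `Cc1ccc(C2=NN(c3ccc(S(C)(=O)=O)cc3)C(=O)CC2)cc1` gives 4720 nM and compound 2 `Cc1cc(O)ccc1C1=NN(c2ccc(S(C)(=O)=O)cc2)C(=O)CC1` gives 14800 nM as the higher of the two numbers, which makes compound 2 the weaker growth inhibitor of the pair. Compound 3 `CCc1ccc(C2=NN(c3ccc(S(C)(=O)=O)cc3)C(=O)CC2)cc1` has 4-ethylphenyl in place of 4-hydroxy-2-methylphenyl on a carbon with a double bond to nitrogen, a change summed up as 4-ethylphenyl in place of 4-hydroxy-2-methylphenyl on a carbon with a double bond to nitrogen in the structures. For the measured compounds named here, only one measured step bears on this, namely a 3.1-fold higher number from compound 1 to compound 2 (0.50 log units; beyond the scatter) on moving to the 4-hydroxy-2-methylphenyl group. Compound 3 gives that group up again, so in this assay a step of similar modest size toward a lower number is expected, although the 4-ethylphenyl group itself is still unmeasured. The estimated change is a 3.0-fold lower number from compound 2 to compound 3 (0.47 log units; beyond the scatter) overall. For compound 3 the estimated value is 5000 nM with an expected range from 2000 nM to 12500 nM in repeated measurements.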

Compound 3, concentration for 50% growth inhibition: 5230 nM
The estimate for compound 3 lay 1.0-fold (0.02 log units) below the measured number, and the stated range covers the measured number.
By their numbers in this assay, from the lowest: compounds 1 and 3 (each within the scatter of the next); then compound 2.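

In this assay, replacing the 4-hydroxy-2-methylphenyl group brings a 2.8-fold lower number from compound 2 to compound 3 (0.45 log units; beyond the scatter), so the higher number of compound 2 belongs to that group and does not extend to the 4-ethylphenyl group. Adding one carbon to the chain on the phenyl ring gives a 1.1-fold higher number from compound 1 to compound 3 (0.04 log units; within the scatter), which lies within the scatter, so the 4-methylphenyl and 4-ethylphenyl groups cannot be told apart at this position. No measurement shown explains either step.

From the compounds shown here alone, it remains open whether the hydroxyl or the methyl of the 4-hydroxy-2-methylphenyl group accounts for the higher number of compound 2, since the two change together in that group. Going by these compounds, it is also open whether a longer chain such as propyl, or an amine on the phenyl ring, would keep the number of the two simpler groups.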